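The source may hold more compounds than are shown below. What is called first, only, known or untested is meant among the compounds shown, and "the series" means these compounds.

The measured compounds:
compound 1 `O=C1NC(=S)/C(=C/c2ccccc2Cl)S1` — -11.5% in a functional assay on HEp-2 cells (Homo sapiens) for cytotoxicity, read by MTT assay, with a stated time of 72 h, tested at 2.5 ug/mL; a lower number here means less inhibition of growth, a higher number more inhibition of growth at the concentration tested
compound 2 `O=C1NC(=S)/C(=C/c2ccc(Cl)cc2Cl)S1` — 15.3% in this assay

Compound 1 stands lowest of the two numbers in this assay; its nearest neighbour is compound 2, and the step between them is a number 26.8 percentage points higher from compound 1 to compound 2 (beyond the scatter), a change that comes from chloro in place of hydrogen on an aromatic carbon.

Compound 3 `O=C1NC(=S)/C(=C/c2c(Cl)cccc2Cl)S1` has not yet been measured in this assay. It differs from compound 1 by chloro in place of hydrogen on an aromatic carbon. Going by the values given here, the only step that bears on this change is the one from compound 1 to compound 2, where the same kind of exchange, a chloro in place of hydrogen on an aromatic carbon, raised the number by a modest amount beyond the scatter. On that single comparison, a step of similar direction is expected for compound 3 in this assay, though the position of the entering chloro is not the same, so the size may differ.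

Compound 3 is therefore expected to give about 8% in this assay, within a range of -15% to 31%, which means an expected step of a number 19.5 percentage points higher from compound 1 to compound 3 (beyond the scatter).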

Compound 3, percent growth inhibition at one concentration: -4.24%
Beside the measured number, compound 3's estimate is 12.2 percentage points above it; low and high end bracket the measured number.
By their numbers in this assay, from the lowest: compounds 1 and 3 (each within the scatter of the next); then compound 2.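

In this assay, a chloro entering ortho to a group of 8 heavy atoms and meta to a chloro group gives a step (a number 7.3 percentage points higher from compound 1 to compound 3 (within the scatter)) that cannot be told from the usual variation between repeats. The same kind of exchange at a different aromatic carbon gave a larger step (a number 26.8 percentage points higher from compound 1 to compound 2 (beyond the scatter)), so among these compounds a second chloro on the ring does not by itself go with more inhibition of growth, and the outcome depends on the carbon that receives it. No measurement shown here accounts for this difference between the two carbons.

The compounds shown leave open whether an amine, a methoxy group or a carboxylic acid on this same carbon would shift the number in a way the chloro does not, since chloro is the only group that enters in either step. Going by these compounds alone, they also leave open how compound 3 would behave at other concentrations, as its single reading gives no view of a full dose-response curve.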